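Swapping the aryl group from compound 2 to compound 3

The source may report more compounds than this note shows. Statements on the series, on what has been measured and on what is new or still open speak of the compounds shown alone.

Going by the values given here, in a functional assay on KBVIN cells (Homo sapiens) for antiproliferative activity, read by sulforhodamine B assay, with a stated time of 3 days (on this read-out lower numbers stand for an effect already at smaller amounts and higher numbers for an effect only at larger amounts of compound), compound 1 (`CCC1=C(O)c2c(oc(-c3cccc(OC)c3)cc2=O)C(CC)(CC)C1=O`) gives 1.22 uM and compound 2 (`CCC1=C(O)c2c(oc(-c3cccc(F)c3)cc2=O)C(CC)(CC)C1=O`) gives 3.09 uM, the higher of the two numbers so far. The series offers a single measured step, a 2.5-fold higher number from compound 1 to compound 2 (0.40 log units; beyond the scatter), a modest move beyond the scatter that comes with fluoro in place of methoxy on an aromatic carbon.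

The next entry is compound 3 (`CCC1=C(O)c2c(oc(-c3ccc(C)c(C)c3)cc2=O)C(CC)(CC)C1=O`), which has 3,4-dimethylphenyl in place of 3-fluorophenyl on an aromatic carbon. The shared core is unchanged. Among the compounds with values here, the only guide is the step of a 2.5-fold higher number from compound 1 to compound 2 (0.40 log units; beyond the scatter), which concerns the same aryl group but not the same substituents, so it supports only a rough expectation. Within the data shown here, no measured compound carries methyl groups on this ring, and that gap keeps the range wide. Among the measured compounds shown here, compound 3 also loses the fluoro group, and the one compound without it, compound 1, stands at 1.22 uM. A small move toward a lower number is therefore expected in this assay. The estimated step is a 1.8-fold lower number from compound 2 to compound 3 (0.26 log units; within the scatter). Compound 3 is expected at 1.7 uM, with an estimated range of 0.6 uM to 4.5 uM.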

Compound 3, concentration for half-maximal effect: 0.71 uM
Compound 3: the middle estimate sits 2.4-fold (0.38 log units) above what was measured; the measured number falls inside the stated range.
By their numbers in this assay, from the lowest: compounds 3 and 1 (each within the scatter of the next); then compound 2.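

In this assay, the aryl position accepts 3,4-dimethylphenyl as readily as 3-methoxyphenyl, with a 1.7-fold lower number from compound 1 to compound 3 (0.24 log units; within the scatter), so two different substitution patterns on this ring cannot be told apart here. The change from 3-fluorophenyl gives a 4.4-fold lower number from compound 2 to compound 3 (0.64 log units; beyond the scatter), which, together with the earlier step from the methoxy compound, leaves compound 2 alone at the high end, with both of its steps beyond the scatter; the earlier pair could not show whether that gap was specific to the methoxy group, and a ring carrying only carbon substituents now reaches the same level. The data offer no independent measurement that bears on why the fluoro compound stands apart.

The step from compound 2 to compound 3 removes the fluoro group and adds two methyl groups at once, so the contribution of each methyl group, and of losing the fluoro group, remains unresolved. Also open, going by these compounds, is whether a single methyl group would hold the number, and how the assay responds to an amine or a carboxylic acid on this ring.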